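The source may hold more compounds than are shown below. What is called first, only, known or untested is meant among the compounds shown, and "the series" means these compounds.

The series shares one core, varied only on the five-membered aromatic ring of the fused system. Compound 1 `Cc1nc2c(OCc3ccccc3)cccn2c1CO` gives 80% in a functional assay on the whole organism (stomach) for inhibition, with Canis familiaris (Canis lupus familiaris) as the target, at a dose of 5 mg/kg by the intravenous route; on this read-out lower numbers stand for a weaker effect and higher numbers for a stronger effect at the one dose given. Compound 2 `COCc1c(C)nc2c(OCc3ccccc3)cccn12` gives 29% in this assay, and compound 3 `Cc1nc2c(OCc3ccccc3)cccn2c1CS(C)(=O)=O` gives 0% in this assay. Compound 3 stands lowest of the three: the step of a number 80 percentage points lower from compound 1 to compound 3 (beyond the scatter) and the step of a number 29 percentage points lower from compound 2 to compound 3 (beyond the scatter) both set it beyond the scatter below the others, and a number 51 percentage points lower from compound 1 to compound 2 (beyond the scatter) runs in the same direction between the other two. Compound 4 `Cc1nc2c(OCc3ccccc3)cccn2c1Br` differs from compound 3 by bromo in place of (methylsulfonyl)methyl on an aromatic carbon. For the measured compounds named here, no measured step exchanges a group of this kind at that position; the three steps show only that every change made there so far has moved the read-out in this assay by a large or a modest amount, all downward from compound 1. Compound 4 is therefore expected to differ from compound 3 by a number 40 percentage points higher from compound 3 to compound 4 (beyond the scatter) in this assay, a rise carrying wide uncertainty. The estimate for compound 4 in this assay is 40%, within 5% to 80%.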

Compound 4, a percentage reported as inhibition, in the whole organism at one dose (the size of the read-out at that dose, not a potency): 63%
Estimate against measurement, compound 4: 23 percentage points below; the measured number falls inside the stated range.
By their numbers in this assay, from the lowest: compound 3; then compound 2; then compound 4; then compound 1.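

In this assay, the new result shows that a high read-out at this position does not require the hydroxymethyl group: bromo, a single heavy atom, gives a number 63 percentage points higher from compound 3 to compound 4 (beyond the scatter) and a number 34 percentage points higher from compound 2 to compound 4 (beyond the scatter). Bromo does not fully match hydroxymethyl, however, with a number 17 percentage points lower from compound 1 to compound 4 (beyond the scatter), so compound 1 remains highest of the four and the position now shows a graded order rather than only losses from compound 1. No evidence at hand accounts for this order.

As far as these compounds go, it remains open whether a chloro group, an amine, a carboxylic acid or a longer chain such as hydroxyethyl at this position would fall nearer compound 1 or compound 3. Each compound is also shown at only one dose and by one route, so the order may not hold at other doses or by other routes.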